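Cytotoxicity notes on a sulfonate nucleoside series

The source may report more compounds than this note shows. Statements on the series, on what has been measured and on what is new or still open speak of the compounds shown alone.

Of the compounds shown here, three have been measured in a functional assay on MT4 cells (Homo sapiens); on this read-out lower numbers stand for higher toxicity in this test and higher numbers for lower toxicity in this test. Compound 2 `Cc1cn([C@@H]2O[C@H](CO[Si](C)(C)C(C)(C)C)[C@@]3(OS(=O)(=O)C=C3NCC(=O)C(N)=O)[C@H]2O[Si](C)(C)C(C)(C)C)c(=O)n(C)c1=O` gives 9590 nM. Compound 1 `COC(=O)C(=O)CNC1=CS(=O)(=O)O[C@@]12[C@@H](CO[Si](C)(C)C(C)(C)C)O[C@@H](n1cc(C)c(=O)n(C)c1=O)[C@@H]2O[Si](C)(C)C(C)(C)C` gives 10300 nM in this assay; the change between them is methoxy in place of amino on a carbonyl carbon and the step is a 1.1-fold higher number from compound 2 to compound 1 (0.03 log units; within the scatter). Compound 3 `Cc1cn([C@@H]2O[C@H](CO[Si](C)(C)C(C)(C)C)[C@@]3(OS(=O)(=O)C=C3NCCC(N)=O)[C@H]2O[Si](C)(C)C(C)(C)C)c(=O)n(C)c1=O` gives 20000 nM in this assay. Its core differs from that of compound 2 by carbamoylmethyl in place of carbamoylcarbonyl on a saturated chain carbon bound to an amine nitrogen, with a step of a 2.1-fold higher number from compound 2 to compound 3 (0.32 log units; beyond the scatter), while the comparison with compound 1 gives a 1.9-fold higher number from compound 1 to compound 3 (0.29 log units; within the scatter).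

Compound 4 `COC(=O)CCNC1=CS(=O)(=O)O[C@@]12[C@@H](CO[Si](C)(C)C(C)(C)C)O[C@@H](n1cc(C)c(=O)n(C)c1=O)[C@@H]2O[Si](C)(C)C(C)(C)C` has not been measured. It differs from compound 3 by methoxy in place of amino on a carbonyl carbon. Going by the values given here, this is the same kind of change as the one from compound 2 to compound 1, but the place is not identical: in the earlier pair the carbonyl carbon has a carbonyl carbon as its other neighbour, whereas here the other neighbour is a saturated chain carbon.

Among the compounds with values here, the only precedent for this kind of change is the step of a 1.1-fold higher number from compound 2 to compound 1 (0.03 log units; within the scatter), which is within the scatter. With compound 3 at 20000 nM as the starting point, the step from compound 3 to compound 4 in this assay is expected to be of about the same small size, a 1.1-fold higher number from compound 3 to compound 4 (0.02 log units; within the scatter). Within the data shown here, compound 4 is therefore estimated at 21000 nM, with a range from 10000 nM to 44000 nM; this rests on the single step from compound 2 to compound 1 and on the different neighbourhood of the changed carbonyl carbon, which leaves the direction uncertain.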

Compound 4, half-maximal cytotoxic concentration: > 250000 nM
Compound 4 gave a limit, no number (the forecaster's own chance of this, stated with the estimate: 15%); middle value at least 11-fold (1.07 log units) away from the limit.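

In this assay, methoxy in place of amino on a carbonyl carbon does not carry the same size of step from one core to the other: the same change on two cores in this assay, a 1.1-fold higher number (0.03 log units; within the scatter) from compound 2 to compound 1 and an at least 12-fold higher number (1.09 log units; beyond the scatter) from compound 3 to compound 4, at least 11-fold (1.06 log units) apart, beyond the scatter of two such steps

Compound 4 gives a limit of the assay and not a number, so the size of its step stays open on the upper side: the limit of > 250000 nM in this assay, at which 1 of the 4 values shown sits.

The same compound also stands apart from the two compounds with a carbonyl in the chain, with an at least 12-fold higher number from compound 3 to compound 4 (1.09 log units; beyond the scatter) joined by an at least 26-fold higher number from compound 2 to compound 4 (1.41 log units; beyond the scatter) and an at least 24-fold higher number from compound 1 to compound 4 (1.38 log units; beyond the scatter), yet these are single pairs, which show that the earlier step was a poor guide for this core but give no rule for other cores and no cause for the gap.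

On these data alone, it remains open whether a carboxylic acid or an ethyl ester in place of the methyl ester of compound 4 would also reach the limit, and whether the large step depends on the 2-(methoxycarbonyl)ethyl chain as such. A longer chain carrying the same methoxycarbonyl group, set against its primary amide counterpart, would test whether the step seen on the saturated chain holds beyond this one pair.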